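Swapping fluoro for trifluoromethyl on the benzyl group

The source may hold more compounds than are shown below. What is called first, only, known or untested is meant among the compounds shown, and "the series" means these compounds.

Compound 2 `COc1ccc(-c2ccc3c(c2)C(=O)C(=O)N3Cc2ccc(F)cc2)cc1` gives 560 nM in a functional assay on K562 cells (Homo sapiens) for antiproliferative activity, read by MTT assay, with a stated time of 48 h (a higher number here means a weaker inhibitor, a lower number a stronger inhibitor), the highest of the two numbers measured, while compound 3 `COc1ccc(CN2C(=O)C(=O)c3cc(-c4ccc(OC)cc4)ccc32)cc1` gives 30 nM. Compound 1 `O=C1Nc2ccc(-c3ccc(C(F)(F)F)cc3)cc2C1=O` sits at a limit of this assay, > 10000 nM. Compound 4 `COc1ccc(-c2ccc3c(c2)C(=O)C(=O)N3Cc2ccc(C(F)(F)F)cc2)cc1` differs from compound 2 in one place: trifluoromethyl in place of fluoro on an aromatic carbon. For the measured compounds named here, the one measured step at this aromatic carbon, a 19-fold lower number from compound 2 to compound 3 (1.27 log units; beyond the scatter), introduced methoxy rather than trifluoromethyl, so it bears on compound 4 only loosely, though it shows that this position can shift the number a great deal. Going by the values given here, no step with trifluoromethyl at that carbon has been measured, so only a modest change in either direction is expected. Compound 4 is estimated at 500 nM, between 120 nM and 2500 nM. That would be an expected step of a 1.1-fold lower number from compound 2 to compound 4 (0.05 log units; within the scatter).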

Compound 4, half-maximal inhibitory concentration: 270 nM
For compound 4 the middle estimate is 1.9-fold (0.27 log units) above the measured one; the range from low to high includes it.
By their numbers in this assay, from the lowest: compound 3; then compound 4; then compound 2. At a limit, above all of these: compound 1.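

In this assay, trifluoromethyl at this aromatic carbon gives a 2.1-fold lower number from compound 2 to compound 4 (0.32 log units; beyond the scatter), so the position accepts a group of more heavy atoms than fluoro with no loss. Methoxy still gives the lowest number of these three groups, since trifluoromethyl in its place gives a 9.0-fold higher number from compound 3 to compound 4 (0.95 log units; beyond the scatter), which places trifluoromethyl between the other two. Nothing shown here explains why the three groups fall in this order. As far as these compounds go, whether an amine or a carboxylic acid at this carbon would give a number lower than methoxy stays open. So does the effect of a longer chain there.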